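Trimming the Phenyl to Methyl on the Shared Core

The source may hold more compounds than are shown below. What is called first, only, known or untested is meant among the compounds shown, and "the series" means these compounds.

In a functional assay on MCF7 cells (Homo sapiens) for cytotoxicity, read by MTT assay (on this read-out lower numbers stand for stronger inhibition and higher numbers for weaker inhibition), compound 1 `c1ccc(-c2nnc(-c3c[nH]c4ccccc34)o2)cc1` gives 388000 nM, the highest of the three numbers measured. Compound 2 `COc1ccc(-c2nnc(-c3c[nH]c4ccccc34)o2)c(OC)c1OC` gives 121000 nM in this assay, and compound 3 `COc1cc(-c2nnc(-c3cn(C)c4ccccc34)o2)ccc1OCc1ccccc1` gives 35200 nM, both beyond the scatter from compound 1. Compound 4 `Cc1nnc(-c2c[nH]c3ccccc23)o1` differs from compound 1 by methyl in place of phenyl on an aromatic carbon. Within the data shown here, no measured pair shows this change, so its size is unknown; because compound 2 at 121000 nM and compound 3 at 35200 nM carry more at the outer ring and sit lower, removing the ring altogether is expected to give a step upward or none beyond the scatter. For compound 4 a value of 550000 nM is expected, within 180000 nM to 1700000 nM. This estimate means a step of a 1.4-fold higher number from compound 1 to compound 4 (0.15 log units; within the scatter), expected to be small.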

Compound 4, half-maximal inhibitory concentration: 198000 nM
Compound 4: the middle estimate sits 2.8-fold (0.44 log units) above what was measured, and the stated range covers the measured number.
By their numbers in this assay, from the lowest: compound 3; then compounds 2, 4 and 1 (each within the scatter of the next, the first and the last beyond it).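

In this assay, methyl in place of phenyl on this aromatic carbon gives a 2.0-fold lower number from compound 1 to compound 4 (0.29 log units; within the scatter), so on this pair the outer phenyl ring can be lost without a change beyond the scatter. The earlier compounds shown here differ from one another in more than one place and could not show this single change on its own. Nothing measured here gives a reason for this result. The compounds shown leave open whether an amine, a carboxylic acid or a longer chain such as butyl on this same carbon would shift the number beyond the scatter.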